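The source may report more compounds than this note shows. Statements on the series, on what has been measured and on what is new or still open speak of the compounds shown alone.

Two small compounds that share one core have been tested in a functional assay on aorta (Rattus norvegicus); on this read-out higher numbers stand for weaker inhibition and lower numbers for stronger inhibition. Compound 1, `O=c1ccc(CCCO)n[nH]1`, carries a 3-hydroxypropyl chain. In this assay compound 1 reaches only > 100000 nM, which is a limit of the measurement and not a number. Compound 2, `Cn1nc(CO)ccc1=O`, carries a hydroxymethyl group instead. In this assay compound 2 likewise stops at the limit of > 100000 nM. Within the data shown here, both results sit at the limit of > 100000 nM in this assay, at which 2 of the 2 values shown sit, so no step between measured compounds can be computed, and compound 2 stands at that limit and nowhere more precise. Compound 3, `Cn1nc(CCCO)ccc1=O`, differs from compound 2 in one place: 2-hydroxyethyl in place of hydroxy on a saturated chain carbon bound to an aromatic carbon. Among the measured compounds shown here, no measured step guides this change. Compound 1, which already bears the longer chain, stands at the limit of > 100000 nM. The expected step from compound 2 to compound 3 is therefore a number no higher from compound 2 to compound 3 (the limit leaves the size open), nothing beyond the scatter. Compound 3 is estimated at 100000 nM, within 30000 nM to 300000 nM, most likely again reported only as a limit.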

Compound 3, half-maximal inhibitory concentration: > 100000 nM
Compound 3 was reported as a limit (the forecaster's own chance of this, stated with the estimate: 85%); the middle value sits exactly at the limit.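

No new step can be read between compound 3 and either compound 1 or compound 2, since all three results are limits and not numbers: the limit of > 100000 nM in this assay, at which 3 of the 3 values shown sit. The compounds shown leave open whether swapping hydroxymethyl for 3-hydroxypropyl makes any difference in this assay.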